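The compounds below may be only part of what the source reports. "The series", "measured", "known", "first", "only" and "open" are said of these compounds alone.

Compound 3 `CC1(c2ccccc2)CC(S(=O)(=O)c2ccc(F)cc2)=C(c2ccc(/C(N)=N\O)cc2)O1` gives 29700 nM in an ADME assay on J774.A1 cells (Mus musculus) for cytotoxicity, read by MTT assay, with a stated time of 72 h (a lower number here means that less compound is tolerated, a higher number that more compound is tolerated), the highest of the three numbers in hand. Compound 1 `CC1(c2ccc(-c3ccco3)cc2)CC(S(=O)(=O)c2ccc(F)cc2)=C(c2ccc(/C(N)=N\O)cc2)O1` gives 4560 nM and compound 2 `Cc1ccc(-c2ccc(C3(C)CC(S(=O)(=O)c4ccc(F)cc4)=C(c4ccc(/C(N)=N\O)cc4)O3)cc2)cc1` gives 7910 nM in this assay. The two steps that reach compound 3 both remove an aryl group from the same aromatic carbon: a 6.5-fold higher number from compound 1 to compound 3 (0.81 log units; beyond the scatter) and a 3.8-fold higher number from compound 2 to compound 3 (0.57 log units; beyond the scatter). Compound 4 `CC1(c2ccc(-c3ccc(/C(N)=N\O)cc3)cc2)CC(S(=O)(=O)c2ccc(F)cc2)=C(c2ccc(/C(N)=N\O)cc2)O1` reverses that direction, with a group of 10 heavy atoms (7 carbon, 2 nitrogen, 1 oxygen; one six-membered aromatic ring of carbon only) in place of a hydrogen atom, on an aromatic carbon. Each measured step toward a larger group at this carbon gave a lower number, so the step from compound 3 to compound 4 is expected to run the same way, by a 4.2-fold lower number from compound 3 to compound 4 (0.63 log units; beyond the scatter). Compound 4 is estimated at 7000 nM in this assay, with a range from 2500 nM to 20000 nM.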

Compound 4, half-maximal cytotoxic concentration: 3940 nM
Beside the measured number, compound 4's estimate is 1.8-fold (0.25 log units) above it, and the stated range covers the measured number.
By their numbers in this assay, from the lowest: compounds 4, 1 and 2 (each within the scatter of the next); then compound 3.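

In this assay, a ring-bearing group at this aromatic carbon again gives a lower number than hydrogen, now with a group carrying nitrogen and oxygen: a 7.5-fold lower number from compound 3 to compound 4 (0.88 log units; beyond the scatter). The nature of that group separates nothing further, with a 2.0-fold lower number from compound 2 to compound 4 (0.30 log units; within the scatter) and a 1.2-fold lower number from compound 1 to compound 4 (0.06 log units; within the scatter). Compound 1, compound 2 and compound 4 therefore read as one level, set apart only from hydrogen in compound 3.

No measured evidence bears on the reason for this drop. Going by these compounds, whether a methyl group, a fluorine atom or an amine at this carbon would already give the lower number, or an added ring is needed, stays open.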